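Shortening the Chain on the Ring Nitrogen of Compound 3

This account rests on a few compounds, and the source may have more. Where it says the series, first, only, none or still open, it means among the compounds named here.

Among the compounds with values here, in a functional assay on HepG2 cells (Homo sapiens) for antiproliferative activity, read by MTT assay, with a stated time of 48 h (on this read-out lower numbers stand for stronger inhibition of growth and higher numbers for weaker inhibition of growth), compound 3 `CCCCCCCCN(Cc1ccc(C(=O)NO)cc1)c1ncc(-c2ccc(C)cc2)s1` gives 8760 nM, the highest of the three numbers measured so far. Compound 1 `Cc1ccc(-c2cnc(N(Cc3ccc(C(=O)NO)cc3)CC(C)C)s2)cc1` gives 7420 nM and compound 2 `CCCN(Cc1ccc(C(=O)NO)cc1)c1ncc(-c2ccc(C)cc2)s1` gives 2550 nM. Compound 4 `Cc1ccc(-c2cnc(N(Cc3ccc(C(=O)NO)cc3)C(C)C)s2)cc1` differs from compound 3 by isopropyl in place of octyl on a nitrogen on an aromatic ring. Within the data shown here, two steps bear on it: the change a 1.2-fold higher number from compound 1 to compound 3 (0.07 log units; within the scatter), and the change a 3.4-fold higher number from compound 2 to compound 3 (0.54 log units; beyond the scatter). Moving from the long chain back to a short, branched group therefore looks like a reversal of the second step, tempered by the first, so a modest fall in this assay is expected for compound 4, roughly a 2.2-fold lower number from compound 3 to compound 4 (0.34 log units; beyond the scatter). Compound 4 is thus estimated at 4000 nM, with a likely range from 1500 nM to 10000 nM.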

Compound 4, concentration for 50% growth inhibition: 2180 nM
Beside the measured number, compound 4's estimate is 1.8-fold (0.26 log units) above it, and the stated range covers the measured number.
By their numbers in this assay, from the lowest: compounds 4 and 2 (each within the scatter of the next); then compounds 1 and 3 (each within the scatter of the next).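

On the nitrogen on an aromatic ring, isopropyl in place of octyl gives stronger growth inhibition in this assay (a 4.0-fold lower number from compound 3 to compound 4 (0.60 log units; beyond the scatter)), and so does isopropyl in place of isobutyl (a 3.4-fold lower number from compound 1 to compound 4 (0.53 log units; beyond the scatter)). Isopropyl and propyl, however, cannot be told apart (a 1.2-fold lower number from compound 2 to compound 4 (0.07 log units; within the scatter)), so a branch on the carbon bound to this nitrogen brings no loss here, unlike the isobutyl of compound 1. As far as these compounds go, whether a cyclopropyl group or a chain ending in an amine would do better at this position remains open. No measurement shown explains these differences.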